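Notes on a second methoxy group added to compound 2

The source may hold more compounds than are shown below. What is called first, only, known or untested is meant among the compounds shown, and "the series" means these compounds.

Measured so far in a functional assay on ACHN cells (Homo sapiens) for cytotoxicity, read by MTT assay, with a stated time of 48 h; a lower number here means a stronger inhibitor, a higher number a weaker inhibitor:
compound 1 `O=C(Nc1nc2ccc(Cl)cc2s1)c1cc(-c2ccc(F)cc2)n2nc(-c3ccccc3)cc2n1` gives 13800 nM
compound 2 `COc1ccc(-c2cc(C(=O)Nc3nc4ccc(Cl)cc4s3)nc3cc(-c4ccccc4)nn23)cc1` gives 7240 nM

Compound 2 stands at one of two numbers that lie within the scatter of each other; the step of a 1.9-fold lower number from compound 1 to compound 2 (0.28 log units; within the scatter) does not separate the two compounds, so no order is claimed between them.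

Compound 3 `COc1ccc(-c2cc(C(=O)Nc3nc4ccc(Cl)cc4s3)nc3cc(-c4ccccc4)nn23)cc1OC` is unmeasured. It differs from compound 2 by methoxy in place of hydrogen on an aromatic carbon; read one bond further out, 4-methoxyphenyl becomes 3,4-dimethoxyphenyl. Going by the values given here, no measured step adds a group to this ring; the only step known, a 1.9-fold lower number from compound 1 to compound 2 (0.28 log units; within the scatter), exchanges one substituent on the same ring for another and stays within the scatter. A small move of similar size is therefore expected in this assay for compound 3, with the step of a 1.3-fold lower number from compound 2 to compound 3 (0.12 log units; within the scatter) expected. Compound 3 is estimated at 5500 nM, within a range of 2000 nM to 16000 nM.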

Compound 3, half-maximal inhibitory concentration: 7760 nM
Estimate against measurement, compound 3: 1.4-fold (0.15 log units) below, within the range that was stated.
By their numbers in this assay, from the lowest: compounds 2, 3 and 1 (each within the scatter of the next).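

In this assay, adding a methoxy group to the ring gives a 1.1-fold higher number from compound 2 to compound 3 (0.03 log units; within the scatter) and so does not separate the two compounds: on this evidence, the position ortho to a methoxy group and meta to a large group accepts the change from 4-methoxyphenyl to 3,4-dimethoxyphenyl without a readable effect. The larger exchange of 4-fluorophenyl for 3,4-dimethoxyphenyl, a 1.8-fold lower number from compound 1 to compound 3 (0.25 log units; within the scatter) in the same assay, also gives no order, so no ring substituent shown here separates any compound from the others. No accompanying data speak to the reason for this result. The compounds shown leave open whether an amine, a carboxylic acid or a longer alkoxy chain on this ring would move the number beyond the scatter. They also leave open whether changes elsewhere on the shared core would do so.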